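Side-chain amine swap across two fluorine patterns

The compounds below may be only part of what the source reports. "The series", "measured", "known", "first", "only" and "open" are said of these compounds alone.

The set pairs a shared core with a basic side chain on the aromatic nitrogen. Compound 1 `CN(C)CCn1c(=O)c(=Cc2ccc(F)cc2F)s/c1=C1\C(=O)Nc2cc(F)ccc21` and compound 3 `CN(C)CCn1c(=O)c(=Cc2ccc(F)c(F)c2)s/c1=C1\C(=O)Nc2ccc(F)cc21` are built from the same atoms joined differently; the difference between the two cores is not broken down here. Compound 2 `CCN(CC)CCCn1c(=O)c(=Cc2ccc(F)c(F)c2)s/c1=C1\C(=O)Nc2ccc(F)cc21` keeps the core of compound 3 and carries (diethylamino)methyl in place of dimethylamino. In a functional assay on MDA-MB-231 cells (Homo sapiens) for inhibition, read by MTT assay, with a stated time of 72 h (on this read-out lower numbers stand for stronger inhibition and higher numbers for weaker inhibition), compound 1 gives 8440 nM, compound 3 gives 9480 nM and compound 2 gives 1220 nM. The numbers for compound 1 and compound 3 sit within the usual scatter of each other, so no order is drawn between them. Among the compounds with values here, the one structural change in the set that has been measured is (diethylamino)methyl in place of dimethylamino on a saturated chain carbon, two bonds along the chain from an aromatic nitrogen and it gives a 7.8-fold lower number from compound 3 to compound 2 (0.89 log units; beyond the scatter). Compound 4 `CCN(CC)CCCn1c(=O)c(=Cc2ccc(F)cc2F)s/c1=C1\C(=O)Nc2cc(F)ccc21` applies the same change to the core of compound 1: (diethylamino)methyl in place of dimethylamino on a saturated chain carbon, two bonds along the chain from an aromatic nitrogen. The place reads the same word for word in both pairs, so this is the same change, not merely the same kind. Within the data shown here, because the only measured example of it is a 7.8-fold lower number from compound 3 to compound 2 (0.89 log units; beyond the scatter), the expected step here is a 6.0-fold lower number from compound 1 to compound 4 (0.78 log units; beyond the scatter), kept a little short of that size and given a wide range since a single example is all there is. Compound 4 is therefore estimated at 1400 nM, expected to fall between 500 nM and 4000 nM.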

Compound 4, half-maximal inhibitory concentration: 2100 nM
The estimate for compound 4 lay 1.5-fold (0.18 log units) below the measured number; measured number inside the range.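

In this assay, (diethylamino)methyl in place of dimethylamino on a saturated chain carbon, two bonds along the chain from an aromatic nitrogen, gives a 4.0-fold lower number from compound 1 to compound 4 (0.60 log units; beyond the scatter), and the comparison with the earlier pair finds no difference in the size of the step: the same change on two cores in this assay, a 7.8-fold lower number (0.89 log units; beyond the scatter) from compound 3 to compound 2 and a 4.0-fold lower number (0.60 log units; beyond the scatter) from compound 1 to compound 4, 1.9-fold (0.29 log units) apart, within the scatter of two such steps. The change therefore carries from the core of compound 3 to the core of compound 1 with the same direction and, within the scatter, a similar size. This rests on just two pairs, so it says nothing about cores beyond these two, and neither pair separates the longer chain from the larger substituents on the amine, since 2-(dimethylamino)ethyl becomes 3-(diethylamino)propyl in a single change.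

The compounds shown leave open whether 3-(dimethylamino)propyl or 2-(diethylamino)ethyl alone would give some or all of the step on either core. They also leave open how a cyclic amine such as morpholine, or a chain longer than 3-(diethylamino)propyl, would behave on these two cores.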